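Cytotoxicity of a propoxy lactone and its difluoromethoxybenzyl analogue

The source may report more compounds than this note shows. Statements on the series, on what has been measured and on what is new or still open speak of the compounds shown alone.

The study measures cytotoxicity in an ADME assay on RAW264.7 cells (Mus musculus) for cytotoxicity, read by MTT assay, with a stated time of 24 h, in the absence of a further agent; a lower number here means a stronger inhibitor, a higher number a weaker inhibitor. Compound 1 `CCCOc1ccc(C(O)C2OC(=O)c3c(OC)cc(OC)cc32)cc1` is the starting point of this account. In this assay compound 1 gives > 40000 nM, which is a limit of the assay and not a number. Compound 2 `C=CCCOc1ccc(C(O)C2OC(=O)c3c(OC)cc(OC)cc32)cc1` is its close relative. In this assay compound 2 gives > 40000 nM, again a limit rather than a number. Among the measured compounds shown here, the step from one to the other, a step that the two limits leave unreadable from compound 1 to compound 2, therefore cannot be read, and the only evidence on the measured pair is the limit of > 40000 nM in this assay, at which 2 of the 2 values shown sit.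

Compound 3 `COc1cc(OC)c2c(c1)C(C(O)c1ccc(OCc3ccc(OC(F)F)cc3)cc1)OC2=O` differs from compound 1 by 4-(difluoromethoxy)phenyl in place of ethyl on a saturated chain carbon bound to an oxygen on an aromatic ring. For the measured compounds named here, no measured step in this set bears on this change, and nothing in the measurements speaks to any effect of the entering group. With both measured compounds sitting at the limit, there is no basis to expect compound 3 to leave it, though a numerical value cannot be ruled out. The estimated step is a number no higher from compound 1 to compound 3 (the limit leaves the size open). Compound 3 is expected to give about 40000 nM in this assay, within a range of 12000 nM to 120000 nM.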

Compound 3, half-maximal inhibitory concentration: > 40000 nM
Compound 3: only a limit was reported; the forecaster's own chance of this, stated with the estimate: 65%; the middle value lies on the limit itself.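

In this assay compound 3 gives > 40000 nM, a limit of the assay and not a number. Among the compounds shown here, the steps from compound 1 and compound 2 to compound 3 therefore cannot be read, and the only evidence is: the limit of > 40000 nM in this assay, at which 3 of the 3 values shown sit. The compounds shown leave open whether any of the three differs from the others in this assay.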